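Replacing Nitro with Diethoxymethyl: An Expectation for Compound 4

This account rests on a few compounds, and the source may have more. Where it says the series, first, only, none or still open, it means among the compounds named here.

Three measured compounds share one core and differ only in the group carried on one carbon of the aromatic ring. Compound 1 `CC1=C(/C=C/C(=O)/C=C/c2ccccc2)C(C)(C)CCC1O` carries hydrogen there, and in a functional assay on PC-3 cells (Homo sapiens) for cytotoxicity, read by MTT assay, with a stated time of 72 h (on this read-out higher numbers stand for weaker inhibition and lower numbers for stronger inhibition), compound 1 gives 15500 nM. Compound 2 `CC1=C(/C=C/C(=O)/C=C/c2cccc(F)c2)C(C)(C)CCC1O` carries fluorine; in this assay compound 2 gives 16000 nM, and the step of a 1.0-fold higher number from compound 1 to compound 2 (0.01 log units; within the scatter) shows that this exchange made no real difference. Compound 3 `CC1=C(/C=C/C(=O)/C=C/c2cccc([N+](=O)[O-])c2)C(C)(C)CCC1O` carries a nitro group; in this assay compound 3 gives 5800 nM, the lowest of the three numbers, set apart by a 2.7-fold lower number from compound 1 to compound 3 (0.43 log units; beyond the scatter) and by a 2.8-fold lower number from compound 2 to compound 3 (0.44 log units; beyond the scatter).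

Compound 4 `CCOC(OCC)c1cccc(/C=C/C(=O)/C=C/C2=C(C)C(O)CCC2(C)C)c1` has not been measured. The change from compound 3 is diethoxymethyl in place of nitro on an aromatic carbon. The two steps that bear on it both describe the arrival of nitro, and both brought a modest gain of the same size. Within the data shown here, no measured compound carries diethoxymethyl, so the only guide is that hydrogen and fluorine at this position gave numbers close to each other and higher than nitro. The nitro gain is therefore expected to be lost once nitro leaves, with compound 4 estimated at 13000 nM, in a range from 5000 nM to 32000 nM. This estimate means a step of a 2.2-fold higher number from compound 3 to compound 4 (0.35 log units; beyond the scatter) that is expected to reverse the modest gain seen on the way to compound 3.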

Compound 4, half-maximal inhibitory concentration: 4700 nM
Estimate against measurement, compound 4: 2.8-fold (0.44 log units) above; the measured number lies below the stated range.
By their numbers in this assay, from the lowest: compounds 4 and 3 (each within the scatter of the next); then compounds 1 and 2 (each within the scatter of the next).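

In this assay, putting diethoxymethyl in place of nitro gives a 1.2-fold lower number from compound 3 to compound 4 (0.09 log units; within the scatter) and so brings no real change, even though the entering group has 7 heavy atoms and the leaving group has 3. The lower numbers at this position therefore do not belong to nitro alone: diethoxymethyl also gives a 3.3-fold lower number from compound 1 to compound 4 (0.52 log units; beyond the scatter) and a 3.4-fold lower number from compound 2 to compound 4 (0.53 log units; beyond the scatter) as modest steps beyond the scatter, so among these four compounds the two larger groups stand apart from hydrogen and fluorine. Nothing measured here explains why two such differently built groups give numbers this close, and the two-group resemblance rests on this one cell assay alone.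

The compounds shown leave open which part of diethoxymethyl matters, a question that a smaller dimethoxymethyl group, a plain aldehyde or a simple ethyl chain at the same carbon could help to answer. They also leave open whether an amine or a carboxylic acid there would group with nitro and diethoxymethyl or with hydrogen and fluorine, and whether any of these groups would behave the same way on another carbon of the ring.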